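Amide-to-amino exchange on the carbonyl of compound 2

The source may report more compounds than this note shows. Statements on the series, on what has been measured and on what is new or still open speak of the compounds shown alone.

Working notes on a small set sharing one core, read in a functional assay on TK-10 cells (Homo sapiens) for inhibition, read by sulforhodamine B assay, with a stated time of 48 h; a lower number here means a stronger inhibitor of growth, a higher number a weaker inhibitor of growth. Compound 1 `O=C(Nc1cccc(-n2cc(-c3ccncc3)c(-c3ccc(Cl)c(O)c3)n2)c1)Nc1ccc(Cl)c(Cl)c1` reaches only the limit of the assay, > 32500 nM. Compound 3 `O=C(Nc1cccc(-n2cc(-c3ccncc3)c(-c3ccc(Cl)c(O)c3)n2)c1)Nc1cc(C(F)(F)F)cc(C(F)(F)F)c1` gives a measured number, 3580 nM. Compound 2 `COc1cc(-c2nn(-c3cccc(NC(=O)c4ccc(Cl)c(C(F)(F)F)c4)c3)cc2-c2ccncc2)ccc1Cl` also stops at the limit, > 32500 nM. For the measured compounds named here, compound 2 therefore stands among the weaker members here; it is one of the two values sitting at the limit (the limit of > 32500 nM in this assay, at which 2 of the 3 values shown sit), while compound 3 is the only one with a finite reading.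

Compound 4 `COc1cc(-c2nn(-c3cccc(NC(=O)Nc4ccc(Cl)c(C(F)(F)F)c4)c3)cc2-c2ccncc2)ccc1Cl` is the next candidate, differing from compound 2 in one place: (4-chloro-3-(trifluoromethyl)phenyl)amino in place of 4-chloro-3-(trifluoromethyl)phenyl on a carbonyl carbon. Going by the values given here, the added hydrogen-bond donor on that carbonyl carbon is the only change; the rest of compound 2 is kept. Among the compounds with values here, since compound 2 is a limit, no measured step is known for this kind of change, and compound 3 shows only that a finite value can be reached with a different substitution on the core and on the outer ring.

The expected step of an at least 3.6-fold lower number from compound 2 to compound 4 (0.55 log units; beyond the scatter) is a gain beyond the scatter, though a return to the limit is a real possibility. Compound 4 is estimated at 9000 nM, with a range from 2500 nM to 32500 nM.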

Compound 4, concentration for total growth inhibition: 13500 nM
The estimate for compound 4 lay 1.5-fold (0.18 log units) below the measured number; the measured number falls inside the stated range.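

In this assay, for the compounds shown here, replacing 4-chloro-3-(trifluoromethyl)phenyl with (4-chloro-3-(trifluoromethyl)phenyl)amino on a carbonyl carbon gives an at least 2.4-fold lower number from compound 2 to compound 4 (0.38 log units; beyond the scatter), the only readable step in this set and the first sign that this position responds to change. Compound 4 gives a finite reading of 13500 nM, showing that this single exchange is enough to give a measured number. Compound 2 is a limit, so the step is only a bound and its full size cannot be read: the limit of > 32500 nM in this assay, at which 2 of the 4 values shown sit.

Going by these compounds, it remains open whether the gain depends on the hydrogen on the new nitrogen or on the added atom alone. A methylene or an N-methylamino link at the same carbonyl carbon would separate these two readings.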